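The source may report more compounds than this note shows. Statements on the series, on what has been measured and on what is new or still open speak of the compounds shown alone.

Compound 1 `C=CC[C@H]1C[C@@H]([C@@H](O)c2ccccc2)CO[C@@H]1c1ccccc1`: 25400 nM
Compound 2 `O[C@@H](c1ccccc1)[C@H]1CO[C@H](c2ccccc2)[C@@H](C/C=C/c2ccc(F)cc2)C1`: 8340 nM

In a functional assay on HeLa cells (Homo sapiens) for cytotoxicity, read by WST assay, with a stated time of 48 h (on this read-out higher numbers stand for weaker inhibition and lower numbers for stronger inhibition), compound 2 holds the lower of the two numbers. Compound 3 `O[C@@H](c1ccccc1)[C@H]1CO[C@H](c2ccccc2)[C@@H](C/C=C/c2cccnc2)C1` differs from it by pyridin-3-yl in place of 4-fluorophenyl on a double-bonded chain carbon bound to a double-bonded chain carbon: pyridin-3-yl in place of 4-fluorophenyl. Among the compounds with values here, only one measured step bears on this, a 3.0-fold lower number from compound 1 to compound 2 (0.48 log units; beyond the scatter), which is modest and introduced the 4-fluorophenyl-bearing ethenyl group. Within the data shown here, no measured step exchanges one aromatic ring for another, so no shift beyond the scatter is expected, only a slight lean toward a higher number. The expected step is a 1.4-fold higher number from compound 2 to compound 3 (0.16 log units; within the scatter). For compound 3 the estimated value is 12000 nM, within a range of 5000 nM to 28000 nM.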

Compound 3, half-maximal inhibitory concentration: > 100000 nM
Compound 3 gave a limit, no number (the forecaster's own chance of this, stated with the estimate: 10%); middle value at least 8.3-fold (0.92 log units) away from the limit.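

Within the data shown here, the aromatic ring at the end of this chain is not interchangeable: pyridin-3-yl in place of 4-fluorophenyl gives an at least 11-fold higher number from compound 2 to compound 3 (1.07 log units; beyond the scatter) while the earlier compounds showed only a modest gain from the 4-fluorophenyl-bearing ethenyl group. Measured against vinyl, 2-(pyridin-3-yl)ethenyl gives an at least 3.9-fold higher number from compound 1 to compound 3 (0.59 log units; beyond the scatter) and so runs opposite to compound 2, showing that lengthening the chain alone does not set the direction. In this assay compound 3 gives a limit, not a number: the limit of > 100000 nM in this assay, at which 1 of the 3 values shown sits.

On these data alone, whether 4-chlorophenyl or pyridin-4-yl at this place would stay near compound 2 remains open.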